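Thiosemicarbazone series: aromatic substituent swap, growth inhibition

The source may report more compounds than this note shows. Statements on the series, on what has been measured and on what is new or still open speak of the compounds shown alone.

Of the compounds shown here, two have a number so far. Compound 1 `CC1=CC[C@H](C(C)(C)NC(=S)N/N=C/c2ccccc2O)CC1` gives 4600 nM in a functional assay on 786-0 cells (Homo sapiens) for inhibition, read by sulforhodamine B assay, with a stated time of 48 h; a lower number here means a stronger inhibitor of growth, a higher number a weaker inhibitor of growth. Compound 2 `CC1=CC[C@H](C(C)(C)NC(=S)N/N=C/c2ccc(N(C)C)cc2)CC1` gives 87000 nM in this assay, the highest of the two numbers; its nearest neighbour is compound 1, which sits a good deal lower, beyond the scatter. Within the data shown here, no step between measured compounds that differ in one place is available, so the move to compound 3 rests on the structural change alone.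

Compound 3 `CC1=CC[C@H](C(C)(C)NC(=S)N/N=C/c2ccc(Cl)cc2)CC1` differs from compound 2 in one place: chloro in place of dimethylamino on an aromatic carbon. Since compound 2 holds the weakest reading measured so far, the step is expected to go downward, toward a stronger inhibitor, by a moderate margin rather than none at all; the expected step is a 4.4-fold lower number from compound 2 to compound 3 (0.64 log units; beyond the scatter). For compound 3 the estimate in this assay is 20000 nM, with a range from 5000 nM to 80000 nM.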

Compound 3, concentration for 50% growth inhibition: 74900 nM
Estimate against measurement, compound 3: 3.7-fold (0.57 log units) below; low and high end bracket the measured number.
By their numbers in this assay, from the lowest: compound 1; then compounds 3 and 2 (each within the scatter of the next).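

In this assay, chloro in place of dimethylamino on an aromatic carbon, para to a large group, gives a 1.2-fold lower number from compound 2 to compound 3 (0.07 log units; within the scatter) and so leaves the reading within the scatter; at this position, the two groups cannot be told apart. The large difference appears instead with 4-chlorophenyl in place of 2-hydroxyphenyl on a carbon with a double bond to nitrogen, which gives a 16-fold higher number from compound 1 to compound 3 (1.21 log units; beyond the scatter) and leaves compound 1 alone at the low end of the three. Nothing measured bears on the reason for either step.

Whether the hydroxy group itself or its place on the ring accounts for the lower number of compound 1 stays open. Also open, from the compounds shown here alone, is how a carboxylic acid or a primary amine on the same aromatic ring would read in this assay against these three compounds.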